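Bromo substitution on two cores in a cytotoxicity readout

The source may hold more compounds than are shown below. What is called first, only, known or untested is meant among the compounds shown, and "the series" means these compounds.

Compound 1, `CCCNC(=O)[C@@H]1C[C@H]2CCC[C@@H](C1)[C@@H]2NC(=O)c1cc2scnc2n1Cc1ccc(OC)cc1`, was tested in an ADME assay on HEK-293T cells (Homo sapiens) for cytotoxicity, read by luminescence and CellTiter-Glo, with a stated time of 24 h; a higher number here means that more compound is tolerated, a lower number that less compound is tolerated. In this assay compound 1 gives a limit of the assay rather than a number, > 25000 nM. Compound 3, `CCCNC(=O)[C@@H]1C[C@H]2CCC[C@@H](C1)[C@@H]2NC(=O)c1cc2sc(Br)nc2n1Cc1ccc(OC)cc1`, differs from compound 1 by bromo in place of hydrogen on an aromatic carbon. Compound 3 likewise gives only a limit, > 100000 nM. The step that the two limits leave unreadable from compound 1 to compound 3 is therefore not readable, because the two results sit at the limit of > 25000 nM in this assay, at which 1 of the 3 values shown sits, and at the limit of > 100000 nM in this assay, at which 1 of the 3 values shown sits.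

Compound 2, `CCCNC(=O)C1CCN(C(=O)c2cc3occc3n2Cc2ccc(OC)cc2)CC1`, is built on a different core; the difference between the two cores is not broken down here. Among the measured compounds shown here, compound 2 gives the only number in this assay, 37200 nM. Compound 4, `CCCNC(=O)C1CCN(C(=O)c2cc3oc(Br)cc3n2Cc2ccc(OC)cc2)CC1`, has not yet been measured and differs from compound 2 by bromo in place of hydrogen on an aromatic carbon. This is the same kind of change as that from compound 1 to compound 3, but the surroundings differ: in compound 3 the bromo sits on a five-membered aromatic ring with one nitrogen and one sulfur, next to the ring nitrogen and next to the ring sulfur, whereas in compound 4 it sits on a five-membered aromatic ring with one oxygen, next to the ring oxygen.

Since the measured step of this kind gives no readable size, the expectation for compound 4 rests on compound 2 and its value of 37200 nM: the step from compound 2 to compound 4 is expected to be about a 1.1-fold higher number from compound 2 to compound 4 (0.03 log units; within the scatter). Compound 4 is thus estimated at 40000 nM, with a likely range from 15000 nM to 100000 nM.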

Compound 4, half-maximal cytotoxic concentration: 21900 nM
Compound 4: the middle estimate sits 1.8-fold (0.26 log units) above what was measured; the range from low to high includes it.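

On the core of compound 2, in this assay, bromo in place of hydrogen on an aromatic carbon of a five-membered aromatic ring with 1 oxygen gives a 1.7-fold lower number from compound 2 to compound 4 (0.23 log units; within the scatter), and this step lies within the usual scatter, so the change has no size here that can be told apart from repeat measurements. The same change on the core of compound 1 cannot be read, so there is no second size to set beside this one and nothing shows whether the result carries from one core to the other, because compound 3 gives a limit of the assay and not a number: the limit of > 100000 nM in this assay, at which 1 of the 4 values shown sits. Compound 1 also gives a limit of the assay and not a number: the limit of > 25000 nM in this assay, at which 1 of the 4 values shown sits.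

The compounds shown leave open whether chloro, methyl or a nitrile on that same aromatic carbon would give a step beyond the usual scatter on either core. Among the compounds shown here, they also leave open what a carboxylic acid or an amine would do in place of the bromo, and how much the core itself matters, which no pair differing in one place can settle here.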